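The source may hold more compounds than are shown below. What is called first, only, known or untested is meant among the compounds shown, and "the series" means these compounds.

Compound 1 `CNc1nc(NCCCN(C)C)c2sc(-c3ccc(C(F)(F)F)cc3)cc2n1` is the starting point of this comparison. In a physicochemical assay for solubility, at pH 2 (a lower number here means a less soluble compound, a higher number a more soluble compound), compound 1 gives 240 ug/mL, the highest of the three numbers in hand. Compound 2 `CNc1nc(OCCCN(C)C)c2sc(-c3ccc(C(F)(F)F)cc3)cc2n1` sits close by: in this assay compound 2 gives 174 ug/mL, and the step of a 1.4-fold lower number from compound 1 to compound 2 (0.14 log units; within the scatter) does not leave the scatter. Compound 3 `CNc1nc(NC(C)(C)C)c2sc(-c3ccc(C(F)(F)F)cc3)cc2n1` is far away: in this assay compound 3 gives 1.6 ug/mL, so that the step of a 150-fold lower number from compound 1 to compound 3 (2.18 log units; beyond the scatter) is large, as is the step of a 110-fold lower number from compound 2 to compound 3 (2.04 log units; beyond the scatter).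

Compound 4 `CNc1nc(NC2CC2)c2sc(-c3ccc(C(F)(F)F)cc3)cc2n1` has not yet been measured. It differs from compound 1 in one place: cyclopropyl in place of 3-(dimethylamino)propyl on a nitrogen on an aromatic ring. Among the measured compounds shown here, the step that bears most directly on this is the one from compound 1 to compound 3, where the same 3-(dimethylamino)propyl on the same nitrogen was also exchanged for a small carbon-only group, tert-butyl, and the number fell by a 150-fold lower number from compound 1 to compound 3 (2.18 log units; beyond the scatter). The step from compound 2 to compound 3 points the same way. A drop of similar order is therefore expected here, so that the step from compound 1 to compound 4 is estimated at a 60-fold lower number from compound 1 to compound 4 (1.78 log units; beyond the scatter). For compound 4 the expected value in this assay is 4 ug/mL, with a range from 1 ug/mL to 15 ug/mL.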

Compound 4, solubility: 120 ug/mL
Compound 4: middle estimate off by 30-fold (1.48 log units), on the low side, and the stated range ends below it.
By their numbers in this assay, from the lowest: compound 3; then compounds 4, 2 and 1 (each within the scatter of the next).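

At this nitrogen, a carbon-only group need not bring a large step in this assay: cyclopropyl in place of 3-(dimethylamino)propyl gives a result within the scatter (a 2.0-fold lower number from compound 1 to compound 4 (0.30 log units; within the scatter)), and cyclopropylamino in place of 3-(dimethylamino)propoxy also does (a 1.5-fold lower number from compound 2 to compound 4 (0.16 log units; within the scatter)). Removing the chain with its nitrogen therefore does not by itself go with a large step, although compound 3 goes against this, and the outcome depends on which carbon-only group enters, as the large step for cyclopropyl in place of tert-butyl shows (a 75-fold higher number from compound 3 to compound 4 (1.88 log units; beyond the scatter)). Nothing measured here explains why these two carbon-only groups give such different numbers.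

The compounds shown leave open where an isopropyl or a cyclobutyl group on this nitrogen would fall in this assay, and so whether compound 3 is an isolated case or part of a trend among such groups. They also leave open how a carbon-only chain, such as an n-propyl group, would compare with the 3-(dimethylamino)propyl chain of the same length, or how a morpholine at the end of that chain would behave.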